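Fluoro for chloro on the fused ring of compound 3

The source may hold more compounds than are shown below. What is called first, only, known or untested is meant among the compounds shown, and "the series" means these compounds.

Measured so far in an assay on HEK293 cells for inhibition of acid ceramidase (Homo sapiens), with a stated time of 10 min; a higher number here means a weaker inhibitor, a lower number a stronger inhibitor:
compound 1 `O=C(NCCCCc1ccccc1)n1c(=O)oc2ccccc21` gives 64 nM
compound 2 `O=C(NCCCCc1ccc2ccccc2c1)n1c(=O)oc2ccccc21` gives 71 nM
compound 3 `O=C(NCCCCc1ccccc1)n1c(=O)oc2cc(Cl)ccc21` gives 33 nM

Compound 3 holds the lowest of the three numbers in this assay. Compound 1 is its nearest neighbour: the step from compound 1 to compound 3 is a 1.9-fold lower number from compound 1 to compound 3 (0.29 log units; within the scatter), within the scatter, so the two cannot be ordered. Compound 2 lies somewhat further off, beyond the scatter.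

The next step leads to compound 4 `O=C(NCCCCc1ccccc1)n1c(=O)oc2cc(F)ccc21`, where (fluoro in place of chloro on an aromatic carbon). Among the compounds with values here, only one measured step touches this position, the one from compound 1 to compound 3, in which chloro replaced hydrogen and the number moved by a 1.9-fold lower number from compound 1 to compound 3 (0.29 log units; within the scatter), within the scatter. Since hydrogen and chloro at this position gave numbers this close, no step beyond the scatter is expected in this assay for fluoro either. Compound 4 is therefore expected to give about 45 nM, in the range 22 nM to 95 nM. The expected step from compound 3 to compound 4 is a 1.4-fold higher number from compound 3 to compound 4 (0.13 log units; within the scatter).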

Compound 4, half-maximal inhibitory concentration: 31 nM
For compound 4 the middle estimate is 1.5-fold (0.16 log units) above the measured one, and the stated range covers the measured number.
By their numbers in this assay, from the lowest: compounds 4, 3, 1 and 2 (each within the scatter of the next, the first and the last beyond it).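

In this assay, fluoro and chloro on this aromatic carbon cannot be told apart (a 1.1-fold lower number from compound 3 to compound 4 (0.03 log units; within the scatter)), so the exchange of one for the other has no readable effect in this pair. Fluoro in place of hydrogen gives the first step beyond the scatter at this position (a 2.1-fold lower number from compound 1 to compound 4 (0.31 log units; beyond the scatter)), although it is modest, while the corresponding chloro step stays within the scatter (a 1.9-fold lower number from compound 1 to compound 3 (0.29 log units; within the scatter)). No measurement bearing on the cause of these small steps is available.

Open, from the compounds shown here alone, is whether a methoxy group or an amine on this aromatic carbon would give a number near those of compound 3 and compound 4. Also open, going by these compounds, is whether fluoro on the fused ring of compound 2 would give a step of similar size.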